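Acetyl on the Hydroxyl: From Compound 2 to Compound 3

The compounds below may be only part of what the source reports. "The series", "measured", "known", "first", "only" and "open" are said of these compounds alone.

Two compounds have so far been examined in a physicochemical assay for metabolic stability, read by LC-MS, in phosphate buffer, with a stated time of 3 h, at pH 7.4, tested at 50 uM; on this read-out higher numbers stand for a more stable compound and lower numbers for a less stable compound. Compound 1 `Cc1oc(=O)oc1COC(=O)c1cccc(NC(=O)[C@@H]2C[C@H](SC3=C(C(=O)O)N4C(=O)[C@H]([C@@H](C)O)[C@H]4[C@H]3C)CN2)c1` is one of them. In this assay compound 1 gives > 95%, which is a limit of the assay rather than a number. Compound 2 `C[C@@H](O)[C@H]1C(=O)N2C3=C(S[C@@H]4CN[C@@H](C4)C(=O)Nc4cccc(c4)C(=O)OCOCOC3=O)[C@H](C)[C@H]12` is the other. In this assay compound 2 gives > 95%, again a limit of the assay and not a number. Within the data shown here, compound 2 thus stands at the top of what the read-out can report, and it shares that place with the only other value shown, since both sit at the limit of > 95% in this assay, at which 2 of the 2 values shown sit.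

Compound 3 `CC(=O)O[C@H](C)[C@H]1C(=O)N2C3=C(S[C@@H]4CN[C@@H](C4)C(=O)Nc4cccc(c4)C(=O)OCOCOC3=O)[C@H](C)[C@H]12` has not yet been measured. It differs from compound 2 by acetyl in place of hydrogen on an oxygen on a saturated carbon; read one bond further out, hydroxy becomes acetoxy and 1-hydroxyethyl becomes 1-acetoxyethyl. Among the measured compounds shown here, no step between measured compounds exists to gauge this change, so the expectation rests on the structural change alone. A small decrease, or none beyond the scatter, is expected. The estimated step from compound 2 to compound 3 in this assay is a number at least 5 percentage points lower from compound 2 to compound 3 (that floor lies within the scatter). Compound 3 is expected to give about 90%, within a range from 70% to 99%.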

Compound 3, percent of the compound remaining: > 95%
Compound 3 was reported as a limit (the forecaster's own chance of this, stated with the estimate: 45%); middle value at least 5 percentage points from the limit.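

In this assay compound 3 gives > 95%, which is a limit of the assay and not a number. No step can be read between compound 2 and compound 3, as both stand at the same limit: the limit of > 95% in this assay, at which 3 of the 3 values shown sit.

The compounds shown leave open whether acetyl in place of hydrogen on an oxygen on a saturated carbon changes the read-out of this assay at all.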